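The compounds below may be only part of what the source reports. "The series", "measured", "known", "first", "only" and "open" are said of these compounds alone.

Measured so far in a toxicity assay on THP-1 cells (Homo sapiens) for inhibition; a lower number here means that less compound is tolerated, a higher number that more compound is tolerated:

- compound 1 `COc1ccc(-c2cnc(NC(=O)c3ccccc3F)n2C)cc1`, a limit of the assay: > 100000 nM
- compound 2 `Cn1c(-c2ccccc2)cnc1NC(=O)c1cccc(Cl)c1`, a limit of the assay: > 50000 nM
- compound 3 `COc1ccc(-c2cnc(NC(=O)c3cccc(Cl)c3)n2C)cc1`, a limit of the assay: > 28000 nM

Compound 2 stands on a limit in this assay, not on a number. Within the data shown here, every value in the set is a limit, so no compound can be placed above or below another: one value sits at the limit of > 100000 nM in this assay, at which 1 of the 3 values shown sits, one at the limit of > 28000 nM in this assay, at which 1 of the 3 values shown sits, one at the limit of > 50000 nM in this assay, at which 1 of the 3 values shown sits. Both steps that connect the measured compounds are therefore unreadable: a step that the two limits leave unreadable from compound 1 to compound 3 and a step that the two limits leave unreadable from compound 2 to compound 3.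

Compound 4 `Cn1c(-c2ccccc2)cnc1NC(=O)c1ccc(F)cc1` differs from compound 2 in one place: 4-fluorophenyl in place of 3-chlorophenyl on a carbonyl carbon. Among the measured compounds shown here, the only measured step on the same position, that from compound 1 to compound 3, gives no readable size, and no other step in the set informs the exchange of the aryl group on the carbonyl carbon.

With nothing readable to build on, the step that the limit leaves unreadable from compound 2 to compound 4 is expected to stay within the scatter, and compound 4 is most likely to return a limit again in this assay. Compound 4 is estimated at 100000 nM, with a range from 30000 nM to 300000 nM.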

Compound 4, half-maximal cytotoxic concentration: > 100000 nM
Compound 4: no number, only a limit; the forecaster's own chance of this, stated with the estimate: 85%; the middle value lies on the limit itself.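

In this assay compound 4 gives > 100000 nM, a limit of the assay. Compound 2 gives > 50000 nM, also a limit, so no step can be read between compound 2 and compound 4. The compounds shown leave open where any of them would reach a half-maximal cytotoxic concentration in this assay, and whether either exchange changes it.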